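The source may report more compounds than this note shows. Statements on the series, on what has been measured and on what is new or still open speak of the compounds shown alone.

Measured compounds in a functional assay on MCF7 cells (Homo sapiens) for cytotoxicity, read by MTT assay, with a stated time of 72 h, tested at 1 uM; on this read-out lower numbers stand for less inhibition of growth and higher numbers for more inhibition of growth at the one concentration tested:
- compound 1 `N/C(=N\NC(=S)N1CCOCC1)c1ccccn1` gives 14.7%
- compound 2 `Cc1ccnc(/C(N)=N/NC(=S)N2CCOCC2)c1` gives 1.22%
- compound 3 `Cc1cccc(/C(N)=N/NC(=S)N2CCSCC2)n1` gives 7.3%

Compound 2 stands lowest of the three numbers in this assay; compound 3 lies close to it, within the usual scatter, while compound 1 lies farther off, beyond it. Within the data shown here, the one counted step among the measured compounds, a number 13.5 percentage points lower from compound 1 to compound 2 (beyond the scatter), concerns a methyl in place of hydrogen on an aromatic carbon and does not touch the change now in question.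

Compound 4 `Cc1ccnc(/C(N)=N/NC(=S)N2CCSCC2)c1` differs from compound 2 by thiomorpholin-4-yl in place of morpholin-4-yl on a thiocarbonyl carbon. Among the measured compounds shown here, no measured pair shows this swap alone: compound 3 carries the thiomorpholin-4-yl group but also a differently placed methyl, so its two values next to those of compound 2 show only that both lie within the scatter of each other. On that basis no step beyond the scatter is expected in this assay, with the estimated step being a number 3.8 percentage points higher from compound 2 to compound 4 (within the scatter). Compound 4 is therefore expected to give about 5%, in a range from -4% to 15%.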

Compound 4, percent growth inhibition at one concentration: 3.89%
For compound 4 the middle estimate is 1.1 percentage points above the measured one; the range from low to high includes it.
By their numbers in this assay, from the lowest: compounds 2, 4, 3 and 1 (each within the scatter of the next, the first and the last beyond it).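

In this assay, the exchange on the thiocarbonyl carbon can now be read alone, with the methyl left in place: thiomorpholin-4-yl in place of morpholin-4-yl gives a number 2.7 percentage points higher from compound 2 to compound 4 (within the scatter). Compound 3 could not show this, as it also differs from compound 2 in where its methyl sits. For this one pair, then, the change of ring does not move the growth inhibition beyond the scatter, and no information at hand explains this result.

Going by these compounds, whether a piperidin-1-yl or 4-methylpiperazin-1-yl group in the same place would also stay within the scatter of compound 2 remains open. So does whether the thiomorpholin-4-yl exchange would read the same on the core of compound 1, which gives 14.7%.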